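Morpholine Amide in Place of Hydroxyethyl Amide

The compounds below may be only part of what the source reports. "The series", "measured", "known", "first", "only" and "open" are said of these compounds alone.

Compound 3 `CCCCCCCCN(C)C(=O)Cn1cc(Cc2cnc(=O)n(CC(=O)NCCO)c2)c(=O)nc1SCc1ccc(F)cc1` gives 68% in a functional assay on a cell-free system (plasma) for inhibition of platelet-activating factor acetylhydrolase (Homo sapiens), tested at 100 nM; on this read-out lower numbers stand for less inhibition and higher numbers for more inhibition at the one concentration tested (going by the name of the read-out). Compound 1 `CCCCCCCCN(C)C(=O)Cn1cc(Cc2cnc(=O)n(CC(=O)O)c2)c(=O)nc1SCc1ccc(F)cc1` gives 56% and compound 2 `CCCCCCCCN(C)C(=O)Cn1cc(Cc2cnc(=O)n(CCO)c2)c(=O)nc1SCc1ccc(F)cc1` gives 59%; the step of a number 12 percentage points higher from compound 1 to compound 3 (beyond the scatter) lies beyond the scatter, whereas a number 9 percentage points higher from compound 2 to compound 3 (within the scatter) and a number 3 percentage points higher from compound 1 to compound 2 (within the scatter) do not, so compound 3 stands apart from compound 1 but not from compound 2. Compound 4 `CCCCCCCCN(C)C(=O)Cn1cc(Cc2cnc(=O)n(CC(=O)N3CCOCC3)c2)c(=O)nc1SCc1ccc(F)cc1` differs from compound 3 by morpholin-4-yl in place of (2-hydroxyethyl)amino on a carbonyl carbon. For the measured compounds named here, no measured step swaps one amide substituent for another; the nearest is the change of a carboxy group into the (2-hydroxyethyl)amide. Because a number 12 percentage points higher from compound 1 to compound 3 (beyond the scatter) was only modest, a step of similar or smaller size, in either direction, is expected as a number 3 percentage points lower from compound 3 to compound 4 (within the scatter). Compound 4 is thus expected to give about 65%, between 52% and 78%.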

Compound 4, a percentage reported as inhibition, at one concentration (the size of the read-out at that concentration, not a potency): 64%
Compound 4: the middle estimate sits 1 percentage points above what was measured, within the range that was stated.
By their numbers in this assay, from the lowest: compounds 1, 2, 4 and 3 (each within the scatter of the next, the first and the last beyond it).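

In this assay, morpholin-4-yl in place of (2-hydroxyethyl)amino on the carbonyl carbon brings a six-membered non-aromatic ring and 0 hydrogen-bond donors, and the change reads as a number 4 percentage points lower from compound 3 to compound 4 (within the scatter) on this scale. The position thus takes a swap of one amide substituent for another without a step beyond the scatter, and the further steps, a number 5 percentage points higher from compound 2 to compound 4 (within the scatter) and a number 8 percentage points higher from compound 1 to compound 4 (within the scatter), do not set compound 4 apart from either earlier compound. Nothing at hand gives a reason for these steps.

Still open, from the compounds shown here alone, is whether a piperazine or a dimethylamino group on this carbonyl carbon would give a step beyond the scatter. Also open, going by these compounds, is how a longer chain carrying the amide would read.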